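Open-chain amine in place of piperazine on the core

The source may hold more compounds than are shown below. What is called first, only, known or untested is meant among the compounds shown, and "the series" means these compounds.

Compound 3 `O=C(NCc1ccc(F)cc1)c1nc(Br)c2cccnc2c1N1CCNCC1` is the only one of the three that returns a number in a functional assay on HT-29 cells (Homo sapiens) for cytotoxicity, read by MTT assay, with a stated time of 72 h; a lower number here means a stronger inhibitor, a higher number a weaker inhibitor: compound 3 gives 10000 nM. Compound 1 `CNCCCNc1c(C(=O)NCc2ccc(F)cc2)nc(Br)c2cccnc12` stops at a limit, > 10000 nM. Compound 2 `O=C(NCCCNc1c(C(=O)NCc2ccc(F)cc2)nc(Br)c2cccnc12)c1ccccc1` also stops at a limit, > 10000 nM. Compound 4 `NCCCCCCNc1c(C(=O)NCc2ccc(F)cc2)nc(Br)c2cccnc12` differs from compound 3 by (6-aminohexyl)amino in place of piperazin-1-yl on an aromatic carbon. The measured steps say little: a number no higher from compound 1 to compound 3 (the limit leaves the size open), and a step that the two limits leave unreadable from compound 1 to compound 2. Both rest on (the limit of > 10000 nM in this assay, at which 2 of the 3 values shown sit). Compound 4 carries an open chain ending in an amine, as compound 1 does, and compound 1 shows only its limit > 10000 nM. For compound 4 a weak result is therefore expected, estimated at 15000 nM with a range from 5000 nM to 50000 nM, quite possibly a limit once more. The step of a 1.5-fold higher number from compound 3 to compound 4 (0.18 log units; within the scatter) expected in this assay is accordingly small.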

Compound 4, half-maximal inhibitory concentration: 5000 nM
Compound 4: middle estimate off by 3.0-fold (0.48 log units), on the high side; measured number inside the range.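

In this assay, among these compounds, (6-aminohexyl)amino in place of piperazin-1-yl is the first step at this position with a number at both ends: a 2.0-fold lower number from compound 3 to compound 4 (0.30 log units; within the scatter), so the open chain and the ring cannot be told apart here. Extending the chain with 3-aminopropyl gives an at least 2.0-fold lower number from compound 2 to compound 4 (0.30 log units; that floor lies within the scatter) in place of benzamido and an at least 2.0-fold lower number from compound 1 to compound 4 (0.30 log units; that floor lies within the scatter) in place of methylamino. Both of these steps have only a floor, set by a limit of the assay: the limit of > 10000 nM in this assay, at which 2 of the 4 values shown sit.

As far as these compounds go, whether a carboxylic acid or a hydroxyl group in place of the terminal amine, or a longer chain, would move the number beyond the scatter remains open.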